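Swapping cyano for chloro in a growth inhibition series

This account rests on a few compounds, and the source may have more. Where it says the series, first, only, none or still open, it means among the compounds named here.

compound 1 `O=S(=O)(/C=C/c1ccccc1)Cc1ccc(Nc2ncnc3ccccc23)cc1` in a functional assay on DU-145 cells (Homo sapiens) for inhibition (on this read-out lower numbers stand for stronger inhibition of growth and higher numbers for weaker inhibition of growth), gives 2000 nM
compound 2 `N#Cc1ccc(/C=C/S(=O)(=O)Cc2ccc(Nc3ncnc4ccccc34)cc2)cc1` gives > 100000 nM (a limit, not a number)
compound 3 `CC(C)(C)c1cc(/C=C/S(=O)(=O)Cc2ccc(Nc3ncnc4ccccc34)cc2)cc(C(C)(C)C)c1O` gives 1000 nM

Compound 2 sits at the limit of > 100000 nM in this assay, at which 1 of the 3 values shown sits, and so has no exact number. Compound 4 `O=S(=O)(/C=C/c1ccc(Cl)cc1)Cc1ccc(Nc2ncnc3ccccc23)cc1` differs from compound 2 by a single swap, chloro in place of cyano on an aromatic carbon and nothing else. Within the data shown here, one measured step bears directly on this swap. Putting cyano in place of hydrogen on an aromatic carbon gave an at least 50-fold higher number from compound 1 to compound 2 (1.69 log units; beyond the scatter) and that step was large. Compound 3 also carries no cyano and gives 1000 nM as a real number in this assay too. Chloro itself has not been measured in this series, so the size of its effect remains open. Compound 4 no longer has the cyano group, so a large step towards a lower number, meaning stronger inhibition of growth, is expected. The estimated change is an at least 33-fold lower number from compound 2 to compound 4 (1.52 log units; beyond the scatter) on this reasoning. For compound 4 the expected value is 3000 nM as the middle estimate. The estimated range for compound 4 runs from 800 nM to 20000 nM in all.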

Compound 4, concentration for 50% growth inhibition: > 100000 nM
Compound 4 gave a limit, no number; the forecaster's own chance of this, stated with the estimate: 15%; middle value at least 33-fold (1.52 log units) away from the limit.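

In this assay, chloro in place of hydrogen on the aromatic carbon para to a large group gave an at least 50-fold higher number from compound 1 to compound 4 (1.69 log units; beyond the scatter). The large loss of growth inhibition at this position is therefore not tied to cyano alone, since a second, different group in the same place also gives a large step away from compound 1. Cyano and chloro cannot be ranked against each other, though, as the step between compound 2 and compound 4 cannot be read, each value being a limit of the assay and not a number: the limit of > 100000 nM in this assay, at which 2 of the 4 values shown sit.

Compound 3 carries other groups on this ring and gives 1000 nM, but it differs from compound 1 in more than one place, so it does not show which of its groups is tolerated. The compounds shown leave open whether any single group at this position keeps a measurable value, for example a methyl, a methoxy or an amine, and how far such a group would shift the number from that of compound 1.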